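Propylsulfanyl for Methoxy on a Triazole: Tolerance Expected

A few compounds are considered here, and "the series" means these few. Any claim that something is new, unique, unknown or untested is made for them only; others in the source may bear on it.

Among the compounds with values here, compound 2 `COc1ncn(-c2ncc(OC)c3c(C(=O)C(=O)N4CCN(C(=O)c5ccccc5)CC4)c[nH]c23)n1` is the only compound here with a measured number: in a functional assay on MT2 cells (Homo sapiens) for cytotoxicity, read by XTT assay, with a stated time of 3 days (a lower number here means that less compound is tolerated, a higher number that more compound is tolerated), compound 2 gives 285000 nM. Compound 1 `COc1cnc(-n2cnc(C(=O)N3CCN(C)CC3)n2)c2[nH]cc(C(=O)C(=O)N3CCN(C(=O)c4ccccc4)CC3)c12` gives > 150000 nM in this assay, which is a limit rather than a number. The step between them a step that the limit leaves unreadable from compound 1 to compound 2 stays unreadable because of the limit of > 150000 nM in this assay, at which 1 of the 2 values shown sits. Compound 3 `CCCSc1ncn(-c2ncc(OC)c3c(C(=O)C(=O)N4CCN(C(=O)c5ccccc5)CC4)c[nH]c23)n1` differs from compound 2 by propylsulfanyl in place of methoxy on an aromatic carbon. Within the data shown here, no measured step resembles this change, so nothing in the data points in either direction beyond the scatter. An estimated step of a 1.4-fold lower number from compound 2 to compound 3 (0.15 log units; within the scatter) is expected. Compound 3 is therefore estimated at 200000 nM, within a range from 80000 nM to 400000 nM.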

Compound 3, half-maximal cytotoxic concentration: 7000 nM
The estimate for compound 3 lay 29-fold (1.46 log units) above the measured number; measured number below the stated range.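

In this assay, this position proves sensitive: propylsulfanyl in place of methoxy gives a 41-fold lower number from compound 2 to compound 3 (1.61 log units; beyond the scatter) and so shows that a small swap on the triazole can leave a compound far less tolerated. Propylsulfanyl in place of (4-methylpiperazin-1-yl)carbonyl on the same carbon gives an at least 21-fold lower number from compound 1 to compound 3 (1.33 log units; beyond the scatter) as well. Compound 1 carries a limit rather than a number, so its step to compound 2 cannot be read: the limit of > 150000 nM in this assay, at which 1 of the 3 values shown sits.

Going by these compounds, whether the drop follows the sulfur or the length of the chain stays open. Methylsulfanyl or propoxy on this carbon would separate the two.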